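Swapping an isopropyl for a phenyl on the sulfonamide arm

The source may report more compounds than this note shows. Statements on the series, on what has been measured and on what is new or still open speak of the compounds shown alone.

Of the compounds shown here, two sharing one core have been measured. Compound 1 `COc1cccc(S(=O)(=O)Nc2ccc(F)c(-n3cc(-c4cnc5[nH]nc(OC)c5c4)nn3)c2F)c1` gives 2.3 nM in an assay on Sf9 cells for inhibition of mitogen-activated protein kinase kinase kinase 20 (Homo sapiens), read by ADP-Glo, with a stated time of 30 min; on this read-out higher numbers stand for weaker inhibition and lower numbers for stronger inhibition. Compound 2 `COc1n[nH]c2ncc(-c3cn(-c4c(F)ccc(NS(=O)(=O)c5cccc(C(C)C)c5)c4F)nn3)cc12` gives 6.9 nM in this assay. Among the compounds with values here, compound 2 therefore stands at the higher of the two numbers, the weaker inhibitor, and the one change that separates them, isopropyl in place of methoxy on an aromatic carbon, reads as a 3.0-fold higher number from compound 1 to compound 2 (0.48 log units; beyond the scatter).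

Compound 3 `COc1n[nH]c2ncc(-c3cn(-c4c(F)ccc(NS(=O)(=O)c5cccc(-c6ccccc6)c5)c4F)nn3)cc12` is the next step out from compound 2: phenyl in place of isopropyl on an aromatic carbon. Within the data shown here, the only measured step that touches this position is the one from compound 1 to compound 2, where a larger group at the same aromatic carbon went with a modest rise in the number. On that single precedent, a further enlargement is expected to leave the number where it is or push it somewhat higher, so the estimated step is a 1.4-fold higher number from compound 2 to compound 3 (0.16 log units; within the scatter). For compound 3 the expected value in this assay is 10 nM, with a range from 3 nM to 35 nM.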

Compound 3, half-maximal inhibitory concentration: 4 nM
The estimate for compound 3 lay 2.5-fold (0.40 log units) above the measured number; the range from low to high includes it.
By their numbers in this assay, from the lowest: compounds 1, 3 and 2 (each within the scatter of the next, the first and the last beyond it).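

In this assay, the step from isopropyl to phenyl, a 1.7-fold lower number from compound 2 to compound 3 (0.24 log units; within the scatter), lies within the usual scatter, so this aromatic carbon can carry a whole six-membered aromatic ring of carbon only without a change that these data can resolve. The comparison with the methoxy compound is also within the scatter, at a 1.7-fold higher number from compound 1 to compound 3 (0.24 log units; within the scatter), whereas the isopropyl compound differs from it beyond the scatter, at a 3.0-fold higher number from compound 1 to compound 2 (0.48 log units; beyond the scatter), so among these three compounds the number does not climb steadily as the group grows: compound 3 carries the largest group, yet only compound 2 stands clearly apart from compound 1. Nothing shown here offers an explanation for how these three groups compare.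

What the compounds leave open is how this position responds to groups of a different kind, such as an amine, a carboxylic acid or a morpholine ring, since all three groups shown carry no charge and only methoxy contains an atom other than carbon. Going by these compounds, it is also open whether a phenyl bearing its own substituent, such as a fluorine atom or a methoxy group, would stay within the scatter of compound 3.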